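Removing the cyclopropyl-piperazine: a bridged diamine on the core

The source may hold more compounds than are shown below. What is called first, only, known or untested is meant among the compounds shown, and "the series" means these compounds.

Of the compounds shown here, three sharing one core have been tested in an ADME assay on microsomes from liver (Homo sapiens) for metabolic stability, read by LC-MS, with a stated time of 10 min; a lower number here means that less of the compound is left, a higher number that more of the compound is left. Compound 1 `CN(C[C@H]1Cc2c(cccc2N2CCN(C3CC3)CC2)CN1)[C@H]1CCCc2cccnc21` gives 15.5%, the lowest of the three numbers. Compound 3 `CN(C[C@H]1Cc2c(cccc2N2CCN(c3ncccn3)CC2)CN1)[C@H]1CCCc2cccnc21` gives 35.5%, and compound 2 `FC1(F)CCC(CN(C[C@H]2Cc3c(cccc3N3CCNCC3)CN2)[C@H]2CCCc3cccnc32)CC1` gives 68.6%; compound 2 differs from compound 1 in two places, so only its value is shown, with no single step to compare.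

For the measured compounds named here, the one clean step available is from compound 1 to compound 3, which puts pyrimidin-2-yl in place of cyclopropyl on an amine nitrogen in a ring and is a number 20 percentage points higher from compound 1 to compound 3 (beyond the scatter). That step shows that altering this side of the molecule can shift the read-out modestly, though in one direction only.

Compound 4 `CN(C[C@H]1Cc2c(cccc2N2C[C@H]3C[C@@H]2CN3)CN1)[C@H]1CCCc2cccnc21` goes further: a group of 7 heavy atoms (5 carbon, 2 nitrogen; 2 five-membered non-aromatic rings with 1 hetero atom each) in place of a group of 9 heavy atoms (7 carbon, 2 nitrogen; one three-membered non-aromatic ring of carbon only, one six-membered non-aromatic ring with 2 hetero atoms), on an aromatic carbon. Going by the values given here, no measured step mirrors this exchange, so the expectation rests on compound 1 and the single step to compound 3. A modest rise is expected, and the estimated step is a number 19.5 percentage points higher from compound 1 to compound 4 (beyond the scatter), giving an expected value for compound 4 of 35%, with a range from 15% to 60%.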

Compound 4, percent of the compound remaining: 100%
For compound 4 the middle estimate is 65 percentage points below the measured one; measured number outside the range, above it.
By their numbers in this assay, from the lowest: compound 1; then compound 3; then compound 2; then compound 4.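

In this assay, replacing the 4-cyclopropylpiperazin-1-yl group with the bridged diamine gives a number 84.5 percentage points higher from compound 1 to compound 4 (beyond the scatter), a much larger change than the modest rise seen when only the substituent on the piperazine nitrogen was exchanged. This shows that the group on this aromatic carbon can shift the read-out far more when it is replaced whole. The exchange alters several things at once: the cyclopropyl ring goes, the ring system changes, and a hydrogen-bond donor appears, and no available evidence explains the rise.

The compounds shown cannot separate these features from one another. A methyl group on the free nitrogen of the bridged diamine, or a morpholine at the same aromatic carbon, would help show which feature goes with the higher number.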